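A few compounds are considered here, and "the series" means these few. Any claim that something is new, unique, unknown or untested is made for them only; others in the source may bear on it.

Compound 1 `CC(C)(C)c1ccc(CN(Cc2cccc(CCC(=O)O)c2)S(=O)(=O)c2ccc(Cl)cc2)cc1` — > 3200 nM
Compound 2 `CCCCc1ccc(CN(Cc2cccc(CCC(=O)O)c2)S(C)(=O)=O)cc1` — > 3200 nM
Compound 3 `CCCCC(O)c1ccc(CN(CCCCCCC(=O)O)S(C)(=O)=O)cc1` — > 3200 nM

In an assay on HEK293 cells for inhibition of prostaglandin E2 receptor EP4 subtype (Rattus norvegicus) (on this read-out lower numbers stand for stronger inhibition and higher numbers for weaker inhibition), compound 1 reaches only a limit of the assay, > 3200 nM. Compound 2 likewise shows only a limit, > 3200 nM. Compound 3 gives only a limit as well, > 3200 nM. So compound 3 stands nowhere apart from the others: all three sit at the limit of > 3200 nM in this assay, at which 3 of the 3 values shown sit, and no number separates them.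

Compound 4 `CCCCCC(=O)c1ccc(CN(CCCCCCC(=O)O)S(C)(=O)=O)cc1` has not been measured. It differs from compound 3 in one place: pentylcarbonyl in place of 1-hydroxypentyl on an aromatic carbon. Among the measured compounds shown here, no measured pair of compounds here shows how such a change shifts the result in this assay. Because compound 3 sits at the limit of > 3200 nM in this assay, at which 3 of the 3 values shown sit, together with the other two, the step that the limit leaves unreadable from compound 3 to compound 4 is expected to be small. Compound 4 is therefore estimated at 6000 nM, ranging from 2000 nM to 25000 nM, most likely reported again only as a limit.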

Compound 4, half-maximal inhibitory concentration: > 3200 nM
Compound 4 was reported as a limit (the forecaster's own chance of this, stated with the estimate: 80%); the middle value does not contradict the limit.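

Among the compounds shown here, compound 3 and compound 4 are both reported only as limits, so no step between them can be read: the limit of > 3200 nM in this assay, at which 4 of the 4 values shown sit. In this assay the compounds shown leave open which structural change would give a measured number rather than a limit.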